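This account rests on a few compounds, and the source may have more. Where it says the series, first, only, none or still open, it means among the compounds named here.

Measured in a functional assay on the whole organism with Rattus norvegicus as the target (on this read-out higher numbers stand for an effect only at larger amounts of compound and lower numbers for an effect already at smaller amounts), so far:
Compound 1 `CCOC(=O)C(=O)Nc1cccc(OC)c1C#N` gives 5.3 mg/kg
Compound 2 `CCOC(=O)C(=O)Nc1ccc(N(C)C)cc1C#N` gives 1 mg/kg
Compound 3 `CCCCNc1cccc(NC(=O)C(=O)OCC)c1C#N` gives 0.3 mg/kg

Compound 3 has the lowest number of the three, so it is the one that works at the smallest dose. Compound 2 lies nearest to it and compound 1 furthest away.

Compound 4 `CCOC(=O)C(=O)Nc1cccc([N+](=O)[O-])c1C#N` is still unmeasured. It keeps the shared core but carries nitro in place of butylamino on an aromatic carbon, ortho to a cyano group (nitro in place of butylamino on an aromatic carbon).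

Within the data shown here, only one measured step bears on this change. Putting butylamino in place of methoxy gave an 18-fold lower number from compound 1 to compound 3 (1.25 log units; beyond the scatter), a large step. Compound 4 gives that butylamino up again, so a move back towards the higher number of compound 1 is expected. Among the measured compounds shown here, no nitro compound has been measured, which leaves the size of the move uncertain.

In this assay the expected change is a 10-fold higher number from compound 3 to compound 4 (1.00 log units; beyond the scatter), a clear step beyond the scatter.

For compound 4 the estimate is 3 mg/kg, with an expected range from 0.8 mg/kg to 12 mg/kg.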

Compound 4, dose for half-maximal effect: 0.4 mg/kg
Compound 4: middle estimate off by 7.5-fold (0.88 log units), on the high side, outside the stated range (below it).
By their numbers in this assay, from the lowest: compounds 3 and 4 (each within the scatter of the next); then compound 2; then compound 1.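

In this assay, nitro in place of butylamino on this aromatic carbon, ortho to a cyano group, gives a 1.3-fold higher number from compound 3 to compound 4 (0.12 log units; within the scatter), so in this pair the butyl chain and the hydrogen-bond donor of butylamino are not needed for an effect at a small dose. Nitro in place of methoxy gives a 13-fold lower number from compound 1 to compound 4 (1.12 log units; beyond the scatter), which shows that the large step seen earlier is not tied to butylamino; of the three groups compared at this position, methoxy alone stands apart. Nothing available explains why two such different groups give values within the scatter of each other.

Going by these compounds, it remains open how a carboxylic acid, a primary amine or a chlorine atom would behave at this position. Whether a longer chain on the amine would keep the dose this small is also unknown.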